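Compound 1 to compound 3: losing the phenyl group

The source may report more compounds than this note shows. Statements on the series, on what has been measured and on what is new or still open speak of the compounds shown alone.

- compound 1 `c1ccc(C2=NN(c3ccccc3)C(c3ccc4ccccc4c3)C2)cc1` at 220 nM
- compound 2 `Clc1ccc(C2=NN(c3ccccc3)C(c3ccc4ccccc4c3)C2)cc1` at 160 nM

Going by the values given here, in a functional assay on A549 cells (Homo sapiens) for antiproliferative activity, read by MTT assay, with a stated time of 24 h (a lower number here means a stronger inhibitor of growth, a higher number a weaker inhibitor of growth), compound 1 stands within the scatter of the only other measured number, with a 1.4-fold lower number from compound 1 to compound 2 (0.14 log units; within the scatter) as the sole step. Compound 3 `NC(=S)N1N=C(c2ccccc2)CC1c1ccc2ccccc2c1` brings a group of 3 heavy atoms (1 carbon, 1 nitrogen, 1 sulfur; no ring) in place of a group of 6 heavy atoms (6 carbon; one six-membered aromatic ring of carbon only), on an amine nitrogen in a ring to the core of compound 1. Among the compounds with values here, the sole measured step, chloro in place of hydrogen on an aromatic carbon, concerns a different change, so the data fix no size here. A modest move to a higher number in this assay is expected, with low confidence. The expected step is a 2.3-fold higher number from compound 1 to compound 3 (0.36 log units; beyond the scatter) on this reasoning. For compound 3 the estimated value is 500 nM with an expected range of 120 nM to 2000 nM for now.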

Compound 3, concentration for 50% growth inhibition: 3210 nM
Compound 3: middle estimate off by 6.4-fold (0.81 log units), on the low side; the measured number lies above the stated range.
By their numbers in this assay, from the lowest: compounds 2 and 1 (each within the scatter of the next); then compound 3.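

In this assay, the amine nitrogen in a ring proves sensitive to substitution: replacing phenyl with the group of 3 heavy atoms (1 carbon, 1 nitrogen, 1 sulfur) gives a 15-fold higher number from compound 1 to compound 3 (1.16 log units; beyond the scatter). Going by these compounds alone, this is the first step beyond the scatter, so phenyl at this nitrogen cannot be exchanged for this group without a large loss of growth inhibition. No available evidence bears on the reason for this step.

From the compounds shown here alone, whether the step follows from losing the aromatic ring or from the entering group stays open. A pyridine ring or an acetyl group on this nitrogen would help to separate the two.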